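The source may hold more compounds than are shown below. What is called first, only, known or untested is meant among the compounds shown, and "the series" means these compounds.

Working notes on the series, read in a functional assay on HeLa cells (Homo sapiens) for cytotoxicity, read by MTT assay, with a stated time of 24 h; a higher number here means a weaker inhibitor, a lower number a stronger inhibitor. Compound 1 `COc1ccc(/C=C2\CN(C)C/C(=C\c3ccccc3F)C2=O)cc1OC` gives 14400 nM. Compound 3 `CN1C/C(=C\c2ccc(Br)cc2)C(=O)/C(=C/c2cccc([N+](=O)[O-])c2)C1` gives 11900 nM, which lies within the scatter of the value for compound 1. Compound 2 `COc1cc(/C=C2\CN(C)C/C(=C\c3ccc(Cl)cc3)C2=O)cc(OC)c1OC` reads > 20000 nM, and this is a limit of the assay, not a number. Compound 3 therefore sits with compound 1 among the two numeric results.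

Compound 4 `CN1C/C(=C\c2cccc(Br)c2)C(=O)/C(=C/c2cccc([N+](=O)[O-])c2)C1` is not yet measured and differs from compound 3 in one place: 3-bromophenyl in place of 4-bromophenyl on a double-bonded chain carbon bound to a double-bonded ring carbon. Here 3-bromophenyl stands in place of 4-bromophenyl on a double-bonded chain carbon bound to a double-bonded ring carbon. Among the measured compounds shown here, no measured pair differs in a single place, and the data offer no direct precedent for this change. The expectation in this assay is therefore no step beyond the scatter, in either direction. The estimated change is small, a 1.1-fold higher number from compound 3 to compound 4 (0.02 log units; within the scatter). Compound 4 is expected at 12500 nM, with an estimated range of 6500 nM to 20000 nM.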

Compound 4, half-maximal inhibitory concentration: 11100 nM
Beside the measured number, compound 4's estimate is 1.1-fold (0.05 log units) above it; low and high end bracket the measured number.
By their numbers in this assay, from the lowest: compounds 4, 3 and 1 (each within the scatter of the next). At a limit, above all of these: compound 2.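

In this assay, among the compounds shown here, 3-bromophenyl in place of 4-bromophenyl on a double-bonded chain carbon bound to a double-bonded ring carbon gives a 1.1-fold lower number from compound 3 to compound 4 (0.03 log units; within the scatter), the first step between compounds that differ in one place. At this place, the two bromophenyl groups cannot be told apart in this assay, so moving the bromine around that ring leaves the read-out unchanged within the scatter. No measured property in hand bears on this step.

On these data alone, it remains open whether a different substituent on this phenyl ring, such as an amine or a carboxylic acid, would give a step beyond the scatter at this place. No step shown touches the nitrophenyl group, so its part in the values of compound 3 and compound 4 also stays open.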